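The compounds below may be only part of what the source reports. "The series", "measured", "known", "first", "only" and "open" are said of these compounds alone.

Measured compounds in this series:
compound 1 `COc1nc2ccc(Br)cc2cc1C(c1ccccc1)n1cc(CCCCCO)nn1` gives 8.69%
compound 2 `COc1nc2ccc(Br)cc2cc1C(c1ccccc1)n1cc(CCCO)nn1` gives 13.8%

In an ADME assay on SK-OV-3 cells (Homo sapiens) for cytotoxicity, read by sulforhodamine B assay, with a stated time of 48 h, tested at 10 uM (on this read-out lower numbers stand for less inhibition and higher numbers for more inhibition at the one concentration tested (going by the name of the read-out)), compound 1 stands lowest of the two numbers shown. The nearest number is that of compound 2, reached by a number 5.1 percentage points higher from compound 1 to compound 2 (within the scatter), a step that stays within the scatter, so the two values cannot be told apart and no order between them is claimed.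

Compound 3 `CCOC(=O)c1cn(C(c2ccccc2)c2cc3cc(Br)ccc3nc2OC)nn1` has not yet been measured. Relative to compound 1 it carries the change (ethoxycarbonyl in place of 5-hydroxypentyl on an aromatic carbon). For the measured compounds named here, the only measured step available for comparison is a number 5.1 percentage points higher from compound 1 to compound 2 (within the scatter), which also alters the chain carried on the five-membered aromatic ring with three nitrogens and produced no movement beyond the scatter. That step swaps one hydroxy-bearing chain for a shorter one, whereas the present change brings in an ethoxycarbonyl and removes the 5-hydroxypentyl altogether, so it is only a loose guide. With no measured step beyond the scatter anywhere in the series, no step beyond the scatter is expected in this assay either, in either direction. Compound 3 is therefore estimated at 11%, within a range of 2% to 28%, which corresponds to an expected step of a number 2.3 percentage points higher from compound 1 to compound 3 (within the scatter).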

Compound 3, a percentage reported as inhibition, at one concentration (the size of the read-out at that concentration, not a potency): 2.01%
Compound 3: the middle estimate sits 9 percentage points above what was measured, within the range that was stated.
By their numbers in this assay, from the lowest: compounds 3, 1 and 2 (each within the scatter of the next, the first and the last beyond it).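

In this assay, the aromatic carbon of the five-membered ring with 3 nitrogen now gives its first step beyond the scatter, though a modest one: a number 11.8 percentage points lower from compound 2 to compound 3 (beyond the scatter), with ethoxycarbonyl in place of 3-hydroxypropyl. The same entering group in place of 5-hydroxypentyl gives a number 6.7 percentage points lower from compound 1 to compound 3 (within the scatter), so the exchange reads differently depending on which hydroxy chain leaves, and compound 1 sits within the scatter of both compound 2 and compound 3, which leaves ethoxycarbonyl not cleanly separated from the hydroxy chains as a class. Nothing available here accounts for the step, and it stands as an observation at one concentration only.

Still open, from the compounds shown here alone, is whether the step follows the arrival of the carbonyl or the loss of the hydroxy, which a carboxylic acid, a primary amide or an unsubstituted pentyl chain at this place would help to separate. Also open, going by these compounds, is whether an aminopropyl chain, or a hydroxy chain longer than 5-hydroxypentyl, would move the number beyond the scatter from compound 1.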